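The compounds below may be only part of what the source reports. "The series", "measured", "known", "first", "only" and "open" are said of these compounds alone.

In a functional assay on L1210 cells (Mus musculus) for antiproliferative activity, with a stated time of 48 h (a lower number here means a stronger inhibitor, a higher number a weaker inhibitor), compound 1 `C=C(Br)C(=O)Nc1ccc(/C=C/C(=O)c2ccccc2)cc1` gives 5000 nM and compound 2 `C=C(Br)C(=O)Nc1ccc(C(=O)/C=C/c2ccc(OC)cc2)cc1` gives 900 nM while compound 3 `Nc1ccc(/C=C/C(=O)c2ccccc2)cc1` gives 88000 nM as the highest number of the three. Compound 4 `Cc1ccc(C(=O)/C=C/c2ccc(N)cc2)cc1` carries one change from compound 3, namely methyl in place of hydrogen on an aromatic carbon with methyl in place of hydrogen on an aromatic carbon. Among the measured compounds shown here, the only measured step that changes a single place is an 18-fold higher number from compound 1 to compound 3 (1.25 log units; beyond the scatter) and it is large, but it concerns a group on a nitrogen rather than this carbon, so it offers no direct guide. For the measured compounds named here, no measured step involves a methyl, so no step beyond the scatter is expected, and the direction stays open. The estimated step is a 1.3-fold lower number from compound 3 to compound 4 (0.10 log units; within the scatter) and it stays within the scatter. In this assay the estimate for compound 4 is 70000 nM with an expected range of 25000 nM to 160000 nM for repeat measurements.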

Compound 4, half-maximal inhibitory concentration: 49000 nM
Estimate against measurement, compound 4: 1.4-fold (0.15 log units) above, within the range that was stated.
By their numbers in this assay, from the lowest: compound 2; then compound 1; then compounds 4 and 3 (each within the scatter of the next).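

Putting methyl in place of hydrogen on an aromatic carbon, para to a large group, gives a 1.8-fold lower number from compound 3 to compound 4 (0.25 log units; within the scatter) in this assay. Among the compounds shown here, this position therefore accepts a methyl with no step beyond the scatter, which the earlier compounds could not show, as their only single-place step concerned a group on a nitrogen. No measured evidence here explains this result.

As far as these compounds go, whether a longer chain, an amine or a carboxylic acid on this carbon would also stay within the scatter remains open. So does whether methyl here would give a similar step with the (1-bromoethenyl)carbonyl group on the nitrogen.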